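The source may report more compounds than this note shows. Statements on the series, on what has been measured and on what is new or still open speak of the compounds shown alone.

Of the compounds shown here, three have been measured and a fourth awaits its result. Compound 1 `Cc1cc(-n2ccnc2)c(S(C)(=O)=O)cc1C(=O)N=C(N)N` and compound 2 `Cc1cn(-c2cc(C)c(C(=O)N=C(N)N)cc2S(C)(=O)=O)cn1` share a core, while compound 3 `CS(=O)(=O)c1cc(C(=O)N=C(N)N)ccc1C#N` is built on a different one; compound 4 `Cc1cc(C#N)c(S(C)(=O)=O)cc1C(=O)N=C(N)N` is derived from compound 3. In a functional assay for inhibition of sodium/hydrogen exchanger (Oryctolagus cuniculus) (a higher number here means a weaker inhibitor, a lower number a stronger inhibitor), compound 1 gives 23 nM. In this assay compound 2 gives 28 nM. In this assay compound 3 gives 140 nM, the highest of the three numbers.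

The change from compound 1 to compound 2 is methyl in place of hydrogen on an aromatic carbon. Its effect was a 1.2-fold higher number from compound 1 to compound 2 (0.09 log units; within the scatter). The change from compound 3 to compound 4 is methyl in place of hydrogen on an aromatic carbon. These are the same kind of change but not the same: in the first, the methyl goes onto an aromatic carbon of a five-membered aromatic ring with 2 nitrogen, next to the ring nitrogen; in the second, it goes onto an aromatic carbon of a six-membered aromatic ring of carbon only, ortho to a group of 6 heavy atoms, meta to a cyano group and para to a methylsulfonyl group. How the core of compound 3 differs from the core of compound 1 is not broken down here.

Among the compounds with values here, the only precedent is compound 1 to compound 2, where a 1.2-fold higher number from compound 1 to compound 2 (0.09 log units; within the scatter) stayed within the scatter, so a small step is expected from compound 3 to compound 4, about a 1.2-fold lower number from compound 3 to compound 4 (0.07 log units; within the scatter). Compound 4 is therefore estimated at 120 nM in this assay, expected to lie between 50 nM and 300 nM.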

Compound 4, half-maximal inhibitory concentration: 70 nM
Beside the measured number, compound 4's estimate is 1.7-fold (0.23 log units) above it; measured number inside the range.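

In this assay, methyl in place of hydrogen on an aromatic carbon gives a 2.0-fold lower number from compound 3 to compound 4 (0.30 log units; within the scatter), and set beside the earlier example, the two cores cannot be told apart: the same change on two cores in this assay, a 1.2-fold higher number (0.09 log units; within the scatter) from compound 1 to compound 2 and a 2.0-fold lower number (0.30 log units; within the scatter) from compound 3 to compound 4, 2.4-fold (0.39 log units) apart, within the scatter of two such steps In these two pairs, then, the change carries from one core to the other without a difference that stands out from the scatter, but two small steps cannot show that it would behave the same way on other cores, and the methyl lands on a different kind of ring in each pair, a five-membered aromatic ring with 2 nitrogen in one and a six-membered aromatic ring of carbon only in the other. The remaining steps concern a different change and add nothing on this question: cyano in place of 1H-imidazol-1-yl gives a 3.0-fold higher number from compound 1 to compound 4 (0.48 log units; beyond the scatter), and cyano in place of 4-methyl-1H-imidazol-1-yl gives a 2.5-fold higher number from compound 2 to compound 4 (0.40 log units; beyond the scatter), both beyond the scatter.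

The compounds shown leave open whether a larger group, such as an ethyl or a methoxy, would give an equally small step where the methyl sits on the ring of compound 4. They also leave open what an amine or a carboxylic acid would do in place of the cyano group.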